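The source may report more compounds than this note shows. Statements on the series, on what has been measured and on what is new or still open speak of the compounds shown alone.

Compound 1 `CC1=C(C(=O)Nc2ccc(Br)cc2)C(c2ccc(Cl)cc2Cl)N=C(SCc2ccccc2Cl)N1`: 38.1%. Compound 2 `CC1=C(C(=O)Nc2ccc([N+](=O)[O-])cc2)C(c2ccc(Br)cc2)N=C(SCc2ccccc2)N1`: 37.6%.

In a functional assay on the whole organism (artery, strain albino) with Rattus norvegicus as the target, with a stated time of 360 min, at a dose of 10 mg/kg by the oral route (a higher number here means more inhibition at the dose given (going by the name of the read-out), a lower number less inhibition), compound 2 gives 37.6%, while compound 1 gives 38.1%. The gap between these two numbers lies within the usual scatter of repeated measurements, so neither compound stands apart from the other. Compound 3 `CC1=C(C(=O)Nc2ccc([N+](=O)[O-])cc2)C(c2ccc(Br)cc2)N=C(SCc2ccc(F)cc2)N1` differs from compound 2 by fluoro in place of hydrogen on an aromatic carbon. For the measured compounds named here, no measured pair shows this change, so there is no basis for a shift beyond the scatter. In this assay the expected step is a number 0.4 percentage points higher from compound 2 to compound 3 (within the scatter). Compound 3 is therefore estimated to give 38%, with a range from 24% to 52%.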

Compound 3, a percentage reported as inhibition, in the whole organism at one dose (the size of the read-out at that dose, not a potency): 38.7%
Estimate against measurement, compound 3: 0.7 percentage points below, and the stated range covers the measured number.
By their numbers in this assay, from the lowest: compounds 2, 1 and 3 (each within the scatter of the next).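

In this assay, fluoro in place of hydrogen, para to a large group on the benzyl ring of the benzylsulfanyl substituent, gives a number 1.1 percentage points higher from compound 2 to compound 3 (within the scatter). This first single-place comparison shows that the change from benzylsulfanyl to (4-fluorobenzyl)sulfanyl leaves the read-out within the scatter at this dose. No measured property in the data explains this outcome. On these data alone, whether an amine or a carboxylic acid at this same aromatic carbon would keep the number there stays open, as does any larger replacement, such as a longer chain in place of the benzyl group.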